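A few compounds are considered here, and "the series" means these few. Any claim that something is new, unique, unknown or untested is made for them only; others in the source may bear on it.

Measured compounds, lipophilicity by the NMR partition method:

Compound 1 `OCCC(F)CC(F)(F)F` gives 0.84.
Compound 2 `CC(F)CCO` gives 0.17.
Compound 3 `CC(F)CCCO` gives 0.52.

Notes. In a physicochemical assay for lipophilicity, read by NMR (on this read-out lower numbers stand for lower lipophilicity and higher numbers for higher lipophilicity), compound 1 stands highest of the three, with compound 3 nearest and compound 2 furthest; both gaps are beyond the scatter. Compound 1 and compound 3 do not share a single-point difference, so the difference between the two cores is not broken down here. Compound 3 and compound 2 do: the change is hydroxy in place of hydroxymethyl on a saturated chain carbon, three bonds along the chain from a fluorine atom, and in this assay it reads a number 0.35 log units lower from compound 3 to compound 2 (beyond the scatter), a modest step beyond the scatter.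

Compound 4 `OCC(F)CC(F)(F)F`, not yet measured, is made from compound 1 by hydroxy in place of hydroxymethyl on a saturated chain carbon, two bonds along the chain from a fluorine atom. The place lines differ in one point: in compound 4 the carbon carrying the change sits two bonds along the chain from a fluorine atom, whereas between compound 3 and compound 2 it sits three bonds along. The change is therefore the same kind of change, not the same one. Among the compounds with values here, compound 4 is expected to move by a number 0.35 log units lower from compound 1 to compound 4 (beyond the scatter), resting on the step of a number 0.35 log units lower from compound 3 to compound 2 (beyond the scatter), which is the only measured instance of this kind of change. In this assay compound 4 is estimated at 0.49, with a range from 0.2 to 0.8.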

Compound 4, partition coefficient: 0.6
For compound 4 the middle estimate is 0.11 log units below the measured one; measured number inside the range.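

For hydroxy in place of hydroxymethyl, this assay reads a number 0.24 log units lower from compound 1 to compound 4 (within the scatter) against a number 0.35 log units lower from compound 3 to compound 2 (beyond the scatter) on the other core, so a step that stands beyond the scatter on one core is not reproduced beyond the scatter on the other. This does not show that the change fails to carry over: the new step cannot be told from no change, and the two instances differ in place as well as in core, two bonds along the chain from a fluorine atom in the new pair and three bonds along in the earlier one. No measurement on hand explains why the two readings stand differently against the scatter.

Two instances leave open whether core or place governs the size of this step, and no general rule for the series follows from them. Also open, going by these compounds, is how the same change reads on a core carrying an amine or a carboxylic acid, or on a longer chain.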